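This account rests on a few compounds, and the source may have more. Where it says the series, first, only, none or still open, it means among the compounds named here.

Three compounds share one core and differ only in the aryl group on the sulfonyl sulfur. Compound 1 `COc1cc(C)ccc1S(=O)(=O)NC1=NCCN1C(=S)SN1CCn2c1nsc2=S` carries a 2-methoxy-4-methylphenyl there; in a functional assay on KYSE-510 cells (Homo sapiens) for antiproliferative activity, read by crystal violet staining, with a stated time of 96 h (on this read-out lower numbers stand for stronger inhibition of growth and higher numbers for weaker inhibition of growth), compound 1 gives >= 20000 nM, which is a limit of the assay and not a number. Compound 2 `COc1ccc(OC)c(S(=O)(=O)NC2=NCCN2C(=S)SN2CCn3c2nsc3=S)c1` carries a 2,5-dimethoxyphenyl; in this assay compound 2 gives >= 20000 nM, again a limit. Compound 3 `O=S(=O)(NC1=NCCN1C(=S)SN1CCn2c1nsc2=S)c1ccc(OC(F)(F)F)cc1` carries a trifluoromethoxyphenyl; in this assay compound 3 gives >= 20000 nM, also a limit. Among the measured compounds shown here, the one single-change step among them, a step that the two limits leave unreadable from compound 1 to compound 2, cannot be read since both ends sit at the same limit (the limit of >= 20000 nM in this assay, at which 3 of the 3 values shown sit). Compound 2 thus stands only at the edge of what this assay can report, with no resolved number at all.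

Compound 4 `O=S(=O)(NC1=NCCN1C(=S)SN1CCn2c1nsc2=S)c1ccccc1Cl` differs from compound 2 by 2-chlorophenyl in place of 2,5-dimethoxyphenyl on a sulfonyl sulfur. For the measured compounds named here, no measured step reaches a number on either side, so neither a direction nor a size can be drawn from them; the only guidance is the limit of >= 20000 nM in this assay, at which 3 of the 3 values shown sit. Compound 4 is therefore expected to give 20000 nM in this assay, between 8000 nM and 50000 nM, most likely again reported as a limit. The step expected from compound 2 to compound 4 is a number no higher from compound 2 to compound 4 (the limit leaves the size open), none beyond the scatter.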

Compound 4, concentration for 50% growth inhibition: >= 20000 nM
Compound 4: a limit, no number; the forecaster's own chance of this, stated with the estimate: 80%; the middle value sits exactly at the limit.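

Compound 4 also sits at a limit and gives no number, so the changes from compound 1 and compound 2 to compound 4 cannot be read as steps of any size: the limit of >= 20000 nM in this assay, at which 4 of the 4 values shown sit. The compounds shown leave open whether any aryl group on the sulfonyl sulfur of the shared core gives a resolved number in this assay.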